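From Isopropyl to Propyl on a Carbonyl Carbon

A few compounds are considered here, and "the series" means these few. Any claim that something is new, unique, unknown or untested is made for them only; others in the source may bear on it.

Compound 1 `O=c1[nH]c2ccc(Cl)cc2c(-c2ccccc2Cl)c1CCO`: 380000 nM
Compound 2 `CC(=O)OCCc1c(-c2ccccc2Cl)c2cc(Cl)ccc2[nH]c1=O`: 27000 nM
Compound 3 `CC(C)C(=O)OCCc1c(-c2ccccc2Cl)c2cc(Cl)ccc2[nH]c1=O`: 62000 nM

These values come from an ADME assay on HepG2 2.2.15 cells (Homo sapiens) for cytotoxicity; on this read-out lower numbers stand for higher toxicity in this test and higher numbers for lower toxicity in this test. Compound 3 holds the middle place of the three, with compound 1 higher and compound 2 lower. Compound 4 `CCCC(=O)OCCc1c(-c2ccccc2Cl)c2cc(Cl)ccc2[nH]c1=O` awaits measurement and differs from compound 3 at one place: propyl in place of isopropyl on a carbonyl carbon.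

Among the measured compounds shown here, the closest precedent is a change at that same place, and it was modest: a 2.3-fold higher number from compound 2 to compound 3 (0.36 log units; beyond the scatter). Two larger changes replaced a hydrogen on an oxygen on a saturated carbon, and they bear on the new change only loosely: a 14-fold lower number from compound 1 to compound 2 (1.15 log units; beyond the scatter) and a 6.1-fold lower number from compound 1 to compound 3 (0.79 log units; beyond the scatter). The new change keeps the same atoms, so a smaller shift than the one seen at that place is expected, probably none beyond the scatter and perhaps slightly downward. The expected step is a 1.2-fold lower number from compound 3 to compound 4 (0.09 log units; within the scatter). For compound 4 the estimated value is 50000 nM, with an expected range of 22000 nM to 110000 nM.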

Compound 4, half-maximal cytotoxic concentration: 52000 nM
Compound 4: middle estimate off by 1.0-fold (0.02 log units), on the low side; the range from low to high includes it.
By their numbers in this assay, from the lowest: compounds 2, 4 and 3 (each within the scatter of the next, the first and the last beyond it); then compound 1.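

In this assay, swapping isopropyl for propyl on a carbonyl carbon leaves no readable difference (a 1.2-fold lower number from compound 3 to compound 4 (0.08 log units; within the scatter)), so at this place the two arrangements of the same atoms are not told apart. The earlier compounds shown here put isopropyl beyond the scatter of acetyl, but the propyl chain does not separate from acetyl (a 1.9-fold higher number from compound 2 to compound 4 (0.28 log units; within the scatter)), so the two chains of equal atom count do not stand in the same relation to acetyl. Capping the oxygen with propylcarbonyl still gives a clear drop from the free hydrogen (a 7.3-fold lower number from compound 1 to compound 4 (0.86 log units; beyond the scatter)), as acetyl and isopropylcarbonyl did. As far as these compounds go, whether a longer chain or an amine on that carbonyl carbon would stay in this range remains open. No measurement is available that explains these values.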